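The compounds below may be only part of what the source reports. "The series", "measured", "known", "first", "only" and "open" are said of these compounds alone.

The measured compounds:

In an assay on CHO cells for displacement of a labelled ligand from adenosine receptor A2b (Homo sapiens), read by radioligand binding (on this read-out higher numbers stand for weaker inhibition and lower numbers for stronger inhibition), compound 1 `CCOc1cccc2cc(-c3ccc([N+](=O)[O-])cc3)c(=O)oc12` gives > 30000 nM, which is a limit of the assay and not a number.
In this assay compound 2 `CCOc1cccc2cc(-c3cc(OC)c(OC)c(OC)c3)c(=O)oc12` gives > 30000 nM, again a limit.
In this assay compound 3 `Cc1cccc2cc(-c3ccc([N+](=O)[O-])cc3)c(=O)oc12` gives > 30000 nM, also a limit.

Compound 1 and compound 3 differ by one change, (methyl in place of ethoxy on an aromatic carbon). The step between them, a step that the two limits leave unreadable from compound 1 to compound 3, cannot be read, because all three values sit at the limit of > 30000 nM in this assay, at which 3 of the 3 values shown sit. Compound 2 and compound 1 differ in their cores, and that difference is not broken down here. Compound 4 `COc1cc(-c2cc3cccc(C)c3oc2=O)cc(OC)c1OC` is not yet measured; it stands to compound 2 as compound 3 stands to compound 1, through the same change, (methyl in place of ethoxy on an aromatic carbon).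

The expectation for compound 4 rests on compound 2 alone, whose value in this assay is > 30000 nM, a limit. The step from compound 2 to compound 4 is expected to be a step that the limit leaves unreadable from compound 2 to compound 4, meaning no readable movement. Compound 4 is estimated at 45000 nM, between 15000 nM and 120000 nM, most probably reported again only as a limit.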

Compound 4, inhibition constant: > 30000 nM
Compound 4 was reported as a limit; the forecaster's own chance of this, stated with the estimate: 85%; the middle value does not contradict the limit.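

In this assay compound 4 gives > 30000 nM, which is a limit and not a number. No size can be read for the step linking compound 2 and compound 4, or for any other step, because every value sits at the same limit: the limit of > 30000 nM in this assay, at which 4 of the 4 values shown sit.

The compounds shown leave open what methyl in place of ethoxy does to inhibition.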